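Swapping Benzoyl for 4-Methoxybenzyl: Expecting Another Limit

A few compounds are considered here, and "the series" means these few. Any claim that something is new, unique, unknown or untested is made for them only; others in the source may bear on it.

Compound 3 `O=C1Nc2ccc(C(=O)c3ccccc3)cc2/C1=C\c1cccc(OCc2cn(Cc3ccccc3)nn2)c1` was tested in a functional assay on BT-549 cells (Homo sapiens) for inhibition, read by MTT assay, with a stated time of 48 h (a higher number here means a weaker inhibitor, a lower number a stronger inhibitor), and gives only a limit there, > 50000 nM. Compound 1 `O=C1Nc2ccc(F)cc2/C1=C\c1cccc(OCc2cn(Cc3ccccc3)nn2)c1` likewise reaches only a limit in this assay, > 50000 nM. Compound 2 `O=C1Nc2ccc([N+](=O)[O-])cc2/C1=C\c1cccc(OCc2cn(Cc3ccccc3)nn2)c1` also stops at a limit, > 50000 nM. Because the limit of > 50000 nM in this assay, at which 3 of the 3 values shown sit, none of the steps among these three can be sized: a step that the two limits leave unreadable from compound 1 to compound 2, a step that the two limits leave unreadable from compound 1 to compound 3 and a step that the two limits leave unreadable from compound 2 to compound 3. Compound 4 `COc1ccc(Cc2ccc3c(c2)/C(=C\c2cccc(OCc4cn(Cc5ccccc5)nn4)c2)C(=O)N3)cc1` differs from compound 3 by 4-methoxybenzyl in place of benzoyl on an aromatic carbon. For the measured compounds named here, no measured step bears on this change, since every value so far is a limit. Compound 4 is therefore expected to remain at the limit as well. The step of a number no higher from compound 3 to compound 4 (the limit leaves the size open) is estimated to be no real change. The estimate for compound 4 is 50000 nM, between 20000 nM and 200000 nM.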

Compound 4, half-maximal inhibitory concentration: > 50000 nM
Compound 4 gave a limit, no number; the forecaster's own chance of this, stated with the estimate: 85%; the middle value lies on the limit itself.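

Compound 4 ends at a limit, as do compound 1, compound 2 and compound 3, and no step among these four can be read. As far as these compounds go, whether any group at this place gives a measurable number in this assay stays open.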